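The source may hold more compounds than are shown below. What is called first, only, known or untested is meant among the compounds shown, and "the series" means these compounds.

Among the measured compounds shown here, compound 3 `CN[C@H](C)C(=O)NCc1cccc(Cn2nc(NS(=O)(=O)c3ccc(Cl)s3)c3c(OC)cccc32)c1` sits at the bottom of the three numbers known so far in a physicochemical assay for lipophilicity (on this read-out lower numbers stand for lower lipophilicity and higher numbers for higher lipophilicity), where compound 3 gives 3.1. Compound 1 `COc1cccc2c1c(NS(=O)(=O)c1ccc(Cl)s1)nn2Cc1cccc(CNC(=O)C2CCO2)c1` gives 4.5 in this assay, and compound 2 `COc1cccc2c1c(NS(=O)(=O)c1ccc(Cl)s1)nn2Cc1cccc(CNC(=O)C2CCCO2)c1` gives 4.9, so the shift a number 1.40 log units lower from compound 1 to compound 3 (beyond the scatter) and the shift a number 1.80 log units lower from compound 2 to compound 3 (beyond the scatter) are both large. Compound 4 `COc1cccc2c1c(NS(=O)(=O)c1ccc(Cl)s1)nn2Cc1cccc(CNC(=O)[C@@H]2CCCCN2)c1` has not been measured; it differs from compound 3 in one place: piperidin-2-yl in place of 1-(methylamino)ethyl on a carbonyl carbon. The 1-(methylamino)ethyl group of compound 3 is thus closed into a six-membered ring carrying two more carbons. The most telling comparison is the step of a number 0.40 log units higher from compound 1 to compound 2 (beyond the scatter), where a ring grew by one carbon and the number rose modestly. The two large steps into compound 3 show how far the 1-(methylamino)ethyl group pulled the number down, and compound 4 keeps that same donor and acceptor count, so only a modest rise is expected. The value of compound 4 in this assay is therefore estimated at 3.5, between 3 and 4.1, an expected step of a number 0.40 log units higher from compound 3 to compound 4 (beyond the scatter).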

Compound 4, distribution coefficient: 3.3
Compound 4: middle estimate off by 0.20 log units, on the high side; the measured number falls inside the stated range.
By their numbers in this assay, from the lowest: compounds 3 and 4 (each within the scatter of the next); then compound 1; then compound 2.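

In this assay the step of a number 0.20 log units higher from compound 3 to compound 4 (within the scatter) shows that, on this carbonyl carbon, piperidin-2-yl can replace 1-(methylamino)ethyl without a readable difference, although the smaller ring change in the step of a number 0.40 log units higher from compound 1 to compound 2 (beyond the scatter) did register. The low numbers are therefore not confined to the open chain: the steps of a number 1.20 log units lower from compound 1 to compound 4 (beyond the scatter) and a number 1.60 log units lower from compound 2 to compound 4 (beyond the scatter) place the ring-bearing compound 4 well under the compounds carrying oxetan-2-yl and oxolan-2-yl as well. No measurement shown here gives a reason for these steps.

From the compounds shown here alone, it remains open whether a five-membered pyrrolidin-2-yl ring, a longer amine chain or a carboxylic acid in this place would give a number close to those of compound 3 and compound 4. Going by these compounds, the mirror-image form of the piperidin-2-yl group also remains open.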